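A few compounds are considered here, and "the series" means these few. Any claim that something is new, unique, unknown or untested is made for them only; others in the source may bear on it.

Measured so far in an ADME assay for permeability, using PAMPA; a lower number here means that the compound crosses the layer more slowly, a higher number that the compound crosses the layer faster:
Compound 1 `COc1cc(N2CCN(C(=O)N3CCN(C)CC3)CC2)ccc1Nc1nc(NC2CCCCC2)c2nc[nH]c2n1`: "impermeable" (no number reported)
Compound 2 `COc1cc(N2CCN(Cc3ccccn3)CC2)ccc1Nc1nc(NC2CCCCC2)c2nc[nH]c2n1`: 976 10^-6 cm/s
Compound 3 `COc1cc(N2CCC(CC(=O)N3CCOCC3)CC2)ccc1Nc1nc(NC2CCCCC2)c2nc[nH]c2n1`: 409 10^-6 cm/s

Among the compounds with values here, compound 1 has a verdict rather than a number, so only two numbers can be compared. Of these, compound 3 holds the lower, and compound 2 sits above it by more than the usual scatter between repeat measurements.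

The next compound is compound 4 `COc1cc(N2CCC(CC(=O)N3CCC(N(C)C)C3)CC2)ccc1Nc1nc(NC2CCCCC2)c2nc[nH]c2n1`. It keeps compound 3 intact except for one group on a carbonyl carbon, where 3-(dimethylamino)pyrrolidin-1-yl takes the place of morpholin-4-yl: 3-(dimethylamino)pyrrolidin-1-yl in place of morpholin-4-yl on a carbonyl carbon. Within the data shown here, no pair of measured compounds differs in one place only, so this expectation rests on thin evidence. The nearest guide is compound 1 at "impermeable" (no number reported), which also has a group with a further amine nitrogen on a carbonyl carbon. A clear fall in this assay is therefore expected, and a result with no number remains possible. The estimate amounts to an expected 4.1-fold lower number from compound 3 to compound 4 (0.61 log units; beyond the scatter). Compound 4 is expected at about 100 10^-6 cm/s, within an estimated range of 15 10^-6 cm/s to 400 10^-6 cm/s.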

Compound 4, apparent permeability: "impermeable" (no number reported)
Nothing numeric was reported for compound 4, so the estimate cannot be set against anything.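

In this assay compound 4 gives "impermeable" (no number reported) so no step from compound 3 can be read, and nothing at hand explains this result. The compounds shown leave open how large the gap is between compound 4 and compound 3 at 409 10^-6 cm/s on this scale.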